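This account rests on a few compounds, and the source may have more. Where it says the series, first, only, none or still open, it means among the compounds named here.

Measured in an ADME assay on HEK-293T cells (Homo sapiens) for cytotoxicity, read by CCK-8 assay, with a stated time of 48 h; on this read-out higher numbers stand for weaker inhibition and lower numbers for stronger inhibition:
Compound 1 `COc1ccc(Oc2ccc(C(C)C)cc2-c2ccsc2S(=O)(=O)NCCNC(=S)Nc2ccc([N+](=O)[O-])cc2)cc1OC`: 11400 nM
Compound 2 `COc1ccc(NC(=O)NCCNS(=O)(=O)c2sccc2-c2ccc(C)cc2Oc2ccc(O)c(O)c2)cc1`: > 20000 nM

Compound 2 has only a limit of the assay, > 20000 nM, and not a number. Compound 3 `Cc1ccc(-c2ccsc2S(=O)(=O)NCCNC(=S)Nc2ccc([N+](=O)[O-])cc2)c(Oc2ccc(O)c(O)c2)c1` comes from compound 2 by one change: a group of 12 heavy atoms (7 carbon, 2 nitrogen, 2 oxygen, 1 sulfur; one six-membered aromatic ring of carbon only) in place of a group of 11 heavy atoms (8 carbon, 1 nitrogen, 2 oxygen; one six-membered aromatic ring of carbon only), on an amine nitrogen. The swap takes place on an amine nitrogen. Within the data shown here, no measured step shows what this change does in this assay. Compound 1, which carries the same entering group, gives 11400 nM, so a modest move towards stronger inhibition is expected. The expected step is an at least 1.4-fold lower number from compound 2 to compound 3 (0.15 log units; that floor lies within the scatter). The estimate for compound 3 is 14000 nM, within a range of 6000 nM to 30000 nM.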

Compound 3, half-maximal inhibitory concentration: 8200 nM
Beside the measured number, compound 3's estimate is 1.7-fold (0.23 log units) above it, within the range that was stated.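

On the amine nitrogen, putting the group of compound 3 in place of (4-methoxyphenyl)carbamoyl gives an at least 2.4-fold lower number from compound 2 to compound 3 (0.38 log units; beyond the scatter) in this assay as the first step measured at this position. The reading for compound 2 is a limit of the assay and not a number: > 20000 nM in this assay. The step is therefore only a floor, and its true size may be larger, because compound 2 sits at that limit: the limit of > 20000 nM in this assay, at which 1 of the 3 values shown sits.

The compounds shown leave open whether this swap gives a similar step on another core, and how an acetyl group or a longer chain on this nitrogen would read.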